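The source may hold more compounds than are shown below. What is called first, only, known or untested is meant among the compounds shown, and "the series" means these compounds.

In a functional assay on HT-29 cells (Homo sapiens) for cytotoxicity (a lower number here means a stronger inhibitor, a higher number a weaker inhibitor), compound 1 `CCOC(=O)c1cccnc1S(=O)(=O)NC(=O)Nc1ccc(Cl)cc1` reads > 100000 nM as a limit of the assay, not a number. Compound 2 `CCOC(=O)c1cccnc1SNC(=O)Nc1ncccn1` gives 4800 nM in this assay and so holds the lower of the two actual numbers. Compound 3 `CCOC(=O)c1cccnc1SNC(=O)Nc1nc(OC)cc(OC)n1` gives 96000 nM as the higher number, and its gap to compound 2 lies beyond the usual scatter of repeated measurements.

Compound 4 `CCOC(=O)c1cc([N+](=O)[O-])cnc1SNC(=O)Nc1ncccn1` differs from compound 2 in a single place, with nitro in place of hydrogen on an aromatic carbon of a six-membered aromatic ring with 1 nitrogen, meta to the ethoxycarbonyl group. Among the measured compounds shown here, no measured compound here carries a nitro group, so the expectation stays close to compound 2 at 4800 nM with only a slight drift toward a weaker number. The estimated change is a 1.3-fold higher number from compound 2 to compound 4 (0.10 log units; within the scatter) and is expected to stay within the scatter. For compound 4 the estimate is 6000 nM with an expected range from 1500 nM to 30000 nM as the likely outcome.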

Compound 4, half-maximal inhibitory concentration: > 100000 nM
Compound 4: a limit, no number; the forecaster's own chance of this, stated with the estimate: 10%; middle value at least 16-fold (1.22 log units) from the limit.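

Compounds 1 to 3 all carry hydrogen on this ring carbon, so they gave no reading of what a change here does. In this assay, nitro in place of hydrogen at this carbon, meta to the ethoxycarbonyl group, brings an at least 20-fold higher number from compound 2 to compound 4 (1.31 log units; beyond the scatter), which shows that this position is sensitive and that one substitution here can remove the measurable activity of compound 2. From the compounds shown here alone, the true size of the step stays unknown because compound 4 sits at the top of the measurable range: the limit of > 100000 nM in this assay, at which 2 of the 4 values shown sit.

The compounds shown leave open whether an amine, a methyl group or a chlorine atom at this carbon would keep the activity of compound 2. They also leave open whether nitro here would have the same effect with the dimethoxy-substituted ring of compound 3.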